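A few compounds are considered here, and "the series" means these few. Any claim that something is new, unique, unknown or untested is made for them only; others in the source may bear on it.

In an ADME assay on HS27 cells (Homo sapiens) for antiproliferative activity, read by MTT assay, with a stated time of 24 h (a higher number here means a weaker inhibitor, a lower number a stronger inhibitor), compound 1 `O=C(Nc1ccc(-n2ccc3c(NC(=O)c4ccccc4)ncnc32)cc1)c1ccc(Cl)c(C(F)(F)F)c1` gives 5500 nM. Compound 2 `Nc1ncnc2c1ccn2-c1ccc(NC(=O)Nc2cc(C(F)(F)F)cc(C(F)(F)F)c2)cc1` gives 9500 nM, a number lying within the scatter of that of compound 1. For compound 3 `O=C(Nc1ccc(-n2ccc3c(NC(=O)c4ccccc4)ncnc32)cc1)Nc1cc(C(F)(F)F)cc(C(F)(F)F)c1` this assay reports only a limit, > 10000 nM. That value is the limit of > 10000 nM in this assay, at which 1 of the 3 values shown sits. Compound 2 differs from compound 3 by hydrogen in place of benzoyl on a nitrogen on an aromatic ring, and the step reads an at least 1.0-fold lower number from compound 3 to compound 2 (0.02 log units; that floor lies within the scatter). How the core of compound 1 differs from that of compound 3 is not broken down here. Compound 4 `Nc1ncnc2c1ccn2-c1ccc(NC(=O)c2ccc(Cl)c(C(F)(F)F)c2)cc1` makes the same change from compound 1, namely (hydrogen in place of benzoyl on a nitrogen on an aromatic ring). Because the earlier step of an at least 1.0-fold lower number from compound 3 to compound 2 (0.02 log units; that floor lies within the scatter) rests only on a floor, the expected step of a 1.4-fold lower number from compound 1 to compound 4 (0.14 log units; within the scatter) is taken as a modest lowering of the number. Compound 4 is therefore expected to give 4000 nM, with a range from 1500 nM to 12000 nM.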

Compound 4, half-maximal inhibitory concentration: 5600 nM
Estimate against measurement, compound 4: 1.4-fold (0.15 log units) below; the measured number falls inside the stated range.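

Hydrogen in place of benzoyl on a nitrogen on an aromatic ring reads as a 1.0-fold higher number from compound 1 to compound 4 (0.01 log units; within the scatter) in this assay, so on the core of compound 1 the change leaves the number within the scatter. Set beside the same change on the other core, the two steps compare only in part: the same change on two cores in this assay, an at least 1.0-fold lower number (0.02 log units; that floor lies within the scatter) from compound 3 to compound 2 and a 1.0-fold higher number (0.01 log units; within the scatter) from compound 1 to compound 4; the limit leaves it open whether they differ. For compound 3 the value > 10000 nM is a limit and not a number, so the data neither show that the change carries over unaltered nor show that it does not.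

The compounds shown leave open how a smaller acyl group such as acetyl, or a longer alkyl chain, on that nitrogen would read in this assay. As far as these compounds go, whether the step holds on a third core also remains open.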